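This account rests on a few compounds, and the source may have more. Where it says the series, first, only, none or still open, it means among the compounds named here.

In a functional assay on FaDu cells (Homo sapiens) for cytotoxicity, read by MTT assay, with a stated time of 72 h (a higher number here means that more compound is tolerated, a lower number that less compound is tolerated), three compounds sharing one core have been measured. Compound 3 (`COc1ccc(NC(=O)C(=O)c2cn(C(C)C)c3ccccc23)cn1`) gives 85 nM, the lowest of the three numbers. Compound 1 (`CCOc1ccc(NC(=O)C(=O)c2cn(C(C)C)c3ccccc23)cn1`) gives 175 nM, and compound 2 (`CCn1cc(C(=O)C(=O)Nc2ccc(OC)nc2)c2ccccc21`) gives 219 nM.

Compound 4 (`COc1ccc(NC(=O)C(=O)c2cn(C(C)C)c3ccc(Cl)cc23)cn1`) has chloro in place of hydrogen on an aromatic carbon, in a six-membered aromatic ring of carbon only that is part of a fused or bridged system of two rings: chloro in place of hydrogen on an aromatic carbon.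

Two measured steps offer indirect guidance. Hydrogen in place of methyl on the chain bound to oxygen gives a 2.1-fold lower number from compound 1 to compound 3 (0.31 log units; beyond the scatter). Methyl in place of hydrogen on the chain bound to the aromatic nitrogen gives a 2.6-fold lower number from compound 2 to compound 3 (0.41 log units; beyond the scatter). Among the compounds with values here, both changes lie elsewhere on the core, and no measured compound carries chloro, so neither step gauges this change directly. Within the data shown here, they show only that single-place changes in this small set have moved the number modestly.

A small step is therefore expected in this assay, and the data fix no direction for it. The expected step is a 1.1-fold lower number from compound 3 to compound 4 (0.05 log units; within the scatter). For compound 4 the estimated value is 75 nM, with an expected range from 25 nM to 220 nM.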

Compound 4, concentration lethal to 50% of the cells: > 10000 nM
Compound 4 was reported as a limit (the forecaster's own chance of this, stated with the estimate: 3%); middle value at least 130-fold (2.12 log units) from the limit.
By their numbers in this assay, from the lowest: compound 3; then compounds 1 and 2 (each within the scatter of the next). At a limit, above all of these: compound 4.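

In this assay, chloro on an aromatic carbon of the six-membered aromatic ring of carbon only, meta to a fused ring and para to a fused ring, gives an at least 110-fold higher number from compound 3 to compound 4 (2.07 log units; beyond the scatter). That step is large, whereas the two earlier changes on the chains were modest: a 2.1-fold lower number from compound 1 to compound 3 (0.31 log units; beyond the scatter) and a 2.6-fold lower number from compound 2 to compound 3 (0.41 log units; beyond the scatter). Compound 4 is reported only as a limit, not as a number: the limit of > 10000 nM in this assay, at which 1 of the 4 values shown sits.

This single pair shows that the aromatic carbon, which carries hydrogen in compound 1, compound 2 and compound 3, is a place where one added atom can shift the tolerated concentration far more than either chain change did. The compounds shown hold no other group at this carbon, so it stays open whether the shift belongs to chloro itself or would also follow from fluoro, a nitrile or an amine there. Also open, on these data alone, is whether chloro on another aromatic carbon of this ring would move the number in the same way.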